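The source may report more compounds than this note shows. Statements on the series, on what has been measured and on what is new or still open speak of the compounds shown alone.

In an assay for inhibition of histone-lysine N-methyltransferase EZH2 variant Y641N (Homo sapiens), read by scintillation counting, with a stated time of 60 min, in the presence of a further agent that is not named here (on this read-out lower numbers stand for stronger inhibition and higher numbers for weaker inhibition), compound 2 `Cc1cc(C)c(CN2CCc3c(Cl)cc(-c4c(C)noc4C)c(Cl)c3C2=O)c(=O)[nH]1` gives 1.15 nM, the lowest of the two single numbers shown; its nearest neighbour is compound 1 `Cc1cc(C)c(CN2CCc3c(Cl)cc([C@@H](C)CO)c(Cl)c3C2=O)c(=O)[nH]1`, which gives 260 nM. Compound 3 `Cc1cc(C)c(CN2CCc3c(Cl)cc(C(CO)C4CCOC4)c(Cl)c3C2=O)c(=O)[nH]1` gives 150 nM; 0.38 nM (2 entries), two entries far apart (the several entries of compound 3 in this assay, 150 nM; 0.38 nM (2 entries)), so it offers no single number. Among the compounds with values here, the only measured step, a 230-fold lower number from compound 1 to compound 2 (2.35 log units; beyond the scatter), places 3,5-dimethyl-1,2-oxazol-4-yl where 1-(hydroxymethyl)ethyl stood on the shared core. Compound 4 `COc1cc(C)[nH]c(=O)c1CN1CCc2c(Cl)cc(-c3c(C)noc3C)c(Cl)c2C1=O` differs from compound 2 at another place: methoxy in place of methyl on an aromatic carbon. Within the data shown here, no measured step touches that position, so its effect cannot be read from these data. The step is expected to be a 1.3-fold higher number from compound 2 to compound 4 (0.12 log units; within the scatter), within the scatter. Compound 4 is therefore estimated at 1.5 nM in this assay, between 0.5 nM and 5 nM.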

Compound 4, inhibition constant: 0.15 nM
The estimate for compound 4 lay 10-fold (1.00 log units) above the measured number, and the stated range ends above it.
By their numbers in this assay, from the lowest: compound 4; then compound 2; then compound 1.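

Within the data shown here, the one earlier step changed another place on the shared core, so this position had no reading until now. In this assay, methoxy in place of methyl gives a 7.7-fold lower number from compound 2 to compound 4 (0.88 log units; beyond the scatter), so this position, opposite the ring nitrogen, does affect the number. Nothing shown here explains why this change lowers it. Still open, from the compounds shown here alone, is how an amine or a longer chain such as ethoxy would behave at this position. Also open, going by these compounds, is whether methoxy lowers the number equally when 1-(hydroxymethyl)ethyl replaces 3,5-dimethyl-1,2-oxazol-4-yl elsewhere on the core.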